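Methoxy to Nitro: What to Expect of Compound 4

This account rests on a few compounds, and the source may have more. Where it says the series, first, only, none or still open, it means among the compounds named here.

Of the compounds shown here, three have been measured in an ADME assay on HEK-293T cells (Homo sapiens) for inhibition, read by CCK-8 assay, with a stated time of 48 h, tested at 20 uM (on this read-out lower numbers stand for less inhibition of growth and higher numbers for more inhibition of growth at the one concentration tested), so far. Compound 1 (`N#C/C(=C\c1ccccc1OS(=O)(=O)c1ccc([N+](=O)[O-])cc1)C(=O)Nc1nnc(-c2cccs2)s1`) gives 33% of growth inhibition, compound 2 (`Cc1ccc(S(=O)(=O)Oc2ccccc2/C=C(\C#N)C(=O)Nc2nnc(Cc3cccc4ccccc34)s2)cc1`) gives 23% and compound 3 (`COc1ccc(S(=O)(=O)Oc2ccccc2/C=C(\C#N)C(=O)Nc2nnc(Cc3cccc4ccccc34)s2)cc1`) gives 29% of growth inhibition. Compound 3 therefore stands within the scatter of both other compounds. Compound 4 (`N#C/C(=C\c1ccccc1OS(=O)(=O)c1ccc([N+](=O)[O-])cc1)C(=O)Nc1nnc(Cc2cccc3ccccc23)s1`) has nitro in place of methoxy on an aromatic carbon, para to a large group (nitro in place of methoxy on an aromatic carbon). For the measured compounds named here, the only measured step at this place, methoxy in place of methyl, is a number 6 percentage points higher from compound 2 to compound 3 (within the scatter) and offers no sign of a large change. The (4-nitrophenyl)sulfonyl group also stands in compound 1 (33%), although that compound differs elsewhere. No step beyond the scatter is therefore expected in this assay for this change. The estimated step is a number 1 percentage points higher from compound 3 to compound 4 (within the scatter) and is not expected to exceed the usual scatter. Compound 4 is expected to give 30% of growth inhibition (estimated range 17% to 43%).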

Compound 4, percent growth inhibition at one concentration: 25%
The estimate for compound 4 lay 5 percentage points above the measured number; measured number inside the range.
By their numbers in this assay, from the lowest: compounds 2, 4, 3 and 1 (each within the scatter of the next).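

In this assay, the change from (4-methoxyphenyl)sulfonyl to (4-nitrophenyl)sulfonyl gives (a number 4 percentage points lower from compound 3 to compound 4 (within the scatter)), and nitro in place of methyl gives (a number 2 percentage points higher from compound 2 to compound 4 (within the scatter)), so methyl, methoxy and nitro on this aromatic carbon now stand without a step beyond the scatter. The result also opens a view of the other end of the molecule: with the (4-nitrophenyl)sulfonyl group held constant, (naphthalen-1-yl)methyl in place of thiophen-2-yl gives (a number 8 percentage points lower from compound 1 to compound 4 (within the scatter)). No supporting measurement is available to explain these small steps.

From the compounds shown here alone, whether an amine or a carboxylic acid on this aromatic carbon would give a step beyond the scatter remains open. So does the effect of a longer chain in place of the (naphthalen-1-yl)methyl group.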